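Rat exposure notes: from compound 2 to compound 3

The compounds below may be only part of what the source reports. "The series", "measured", "known", "first", "only" and "open" are said of these compounds alone.

Measured compounds:
compound 1, `Nc1ncc(-c2nc3ccccc3s2)c(N[C@@H]2C[C@H](CO)[C@@H](O)[C@H]2O)n1`: 149 ng.h/mL
compound 2, `Cc1nc(NCC2CC2)nc(N[C@@H]2C[C@H](CO)[C@@H](O)[C@H]2O)c1-c1nc2ccccc2s1`: 1410 ng.h/mL

In an ADME assay on the whole organism (plasma) for pharmacokinetics, with Rattus norvegicus as the target, with a stated time of 6 h, at a dose of 10 mg/kg by the oral route (a lower number here means less compound in the circulation, a higher number more compound in the circulation at the dose given), compound 1 gives 149 ng.h/mL and compound 2 gives 1410 ng.h/mL. Compound 2 therefore stands at the higher of the two numbers, and the gap to compound 1 lies beyond the scatter. Going by the values given here, the two measured compounds differ in several places at once, so no single structural step can be drawn between them; only their two values are known.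

Compound 3, `Cc1nc(NCc2cccs2)nc(N[C@@H]2C[C@H](CO)[C@@H](O)[C@H]2O)c1-c1nc2ccccc2s1`, has not yet been measured in this assay. It differs from compound 2 in one place: thiophen-2-yl in place of cyclopropyl on a saturated chain carbon bound to a nitrogen on an aromatic ring.

Among the compounds with values here, with no measured pair that isolates a change of this kind, nothing in the data says how the swap will move exposure. The expectation is a modest step, if any, from compound 2 to compound 3, most likely downward but plausibly still inside the scatter, estimated as a 1.6-fold lower number from compound 2 to compound 3 (0.19 log units; within the scatter). Compound 3 is accordingly expected to give about 900 ng.h/mL, in a range from 300 ng.h/mL to 2500 ng.h/mL.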

Compound 3, area under the concentration-time curve: 242 ng.h/mL
Beside the measured number, compound 3's estimate is 3.7-fold (0.57 log units) above it; the measured number lies below the stated range.
By their numbers in this assay, from the lowest: compounds 1 and 3 (each within the scatter of the next); then compound 2.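

In this assay, the group on the saturated chain carbon bound to a nitrogen on an aromatic ring turns out to matter: replacing cyclopropyl with thiophen-2-yl gives a 5.8-fold lower number from compound 2 to compound 3 (0.77 log units; beyond the scatter), with the rest of the structure held constant. Going by these compounds alone, this is the first step that isolates a single place, which compound 1 and compound 2 could not do because they differ in several places at once; it shows that this exchange alone can move exposure beyond the scatter. No available measurement bears on what underlies this drop.

Still open, on these data alone, is how exposure responds to other groups at this place, such as a phenyl ring, a longer alkyl chain or a chain carrying an amine, and so whether cyclopropyl stands out or is one of several well-tolerated groups. As far as these compounds go, the step also rests on a single pair, so whether the same exchange would have a similar effect on a different core remains unknown.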